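A few compounds are considered here, and "the series" means these few. Any claim that something is new, unique, unknown or untested is made for them only; others in the source may bear on it.

Working notes on the series in an assay on isolated protein for inhibition of Amine oxidase [flavin-containing] A (Homo sapiens), read by fluorescence and spectrophotometry; on this read-out lower numbers stand for stronger inhibition and higher numbers for weaker inhibition. Of the compounds shown here, three carry a measured number so far. Compound 1 `CC(N)CSc1ccccc1Br` gives 724 nM, compound 2 `CC(N)CSc1ccc(Br)cc1` gives 3890 nM, and compound 3 `CC(N)C[Se]c1ccc(F)cc1` gives 10500 nM. On these numbers compound 3 stands highest of the three; its nearest neighbour is compound 2, whose number lies beyond the scatter below it, and the furthest is compound 1, whose number lies well beyond the scatter below it. For the measured compounds named here, none of these pairs differs in a single place, so no single step between measured compounds can be read off; the values show only that compound 3 is the weakest inhibitor among the three.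

The next compound, compound 4 `CC(N)C[Se]c1ccc(N(C)C)cc1`, differs from compound 3 in one place: dimethylamino in place of fluoro on an aromatic carbon. Going by the values given here, no measured pair in the set reports what this kind of change does in this assay, so there is no step to lean on. The expectation is therefore conservative: a shift of a 1.3-fold lower number from compound 3 to compound 4 (0.12 log units; within the scatter) is estimated, that is, no step beyond the scatter in either direction. For compound 4 the estimate is 8000 nM, with a range from 2500 nM to 25000 nM, pending measurement.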

Compound 4, half-maximal inhibitory concentration: 7150 nM
Compound 4: the middle estimate sits 1.1-fold (0.05 log units) above what was measured; low and high end bracket the measured number.
By their numbers in this assay, from the lowest: compound 1; then compounds 2, 4 and 3 (each within the scatter of the next, the first and the last beyond it).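

In this assay, for the compounds shown here, this is the one step so far that isolates a single place: on an aromatic carbon, para to a group of 5 heavy atoms, dimethylamino in place of fluoro gives a 1.5-fold lower number from compound 3 to compound 4 (0.17 log units; within the scatter), which stays inside the usual scatter. At this position, then, a group of 3 heavy atoms carrying 1 hydrogen-bond acceptor can stand where a single fluorine stood without any change that this read-out can resolve, so compound 3 and compound 4 cannot be told apart here. Nothing at hand offers an account of why the two groups read alike.

The compounds shown leave open how a primary amine, a carboxylic acid or a longer alkyl chain would read on this same aromatic carbon, so the tolerance seen here rests on these two groups alone. Also open, as far as these compounds go, is what sulfur in place of selenium does with the rest of the structure held fixed, and whether bromo on the selenium compounds would read as it does on the sulfur compounds.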